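Adding a Hydroxyalkynyl Chain to Compound 2

The source may hold more compounds than are shown below. What is called first, only, known or untested is meant among the compounds shown, and "the series" means these compounds.

Of the compounds shown here, two have been measured in a functional assay on CCRF-CEM cells (Homo sapiens) for antiproliferative activity, with a stated time of 72 h; on this read-out lower numbers stand for stronger inhibition and higher numbers for weaker inhibition. Compound 1 `OCC#CCSc1cnc2ccccc2c1SCC#CCCl` gives 3.3 ug/mL, and compound 2 `CSc1cnc2ccccc2c1[Se]CC#CCCl` gives 1.7 ug/mL. Compound 2 sits at the lower end of the two numbers, yet its distance to compound 1 is within the usual scatter, so the two cannot be told apart. Compound 3 `OCC#CCSc1cnc2ccccc2c1[Se]CC#CCCl` differs from compound 2 by 3-hydroxyprop-1-yn-1-yl in place of hydrogen on a saturated chain carbon bound to a sulfur; compound 1 already carries the same 4-hydroxybut-2-yn-1-yl group on sulfur. For the measured compounds named here, no measured step guides this change, so compound 3 is expected to show a step of a 1.2-fold higher number from compound 2 to compound 3 (0.07 log units; within the scatter) that stays within the scatter. Compound 3 is estimated at 2 ug/mL, in a range from 0.8 ug/mL to 5 ug/mL.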

Compound 3, concentration for 50% inhibition: 2.6 ug/mL
Compound 3: the middle estimate sits 1.3-fold (0.11 log units) below what was measured; low and high end bracket the measured number.
By their numbers in this assay, from the lowest: compounds 2, 3 and 1 (each within the scatter of the next).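

In this assay, 3-hydroxyprop-1-yn-1-yl in place of hydrogen on a saturated chain carbon bound to a sulfur gives a 1.5-fold higher number from compound 2 to compound 3 (0.18 log units; within the scatter) and shows that this position takes the added chain without a step beyond the scatter. With that chain in place, the change on the aromatic carbon, where a selenium-bearing group stands for a sulfur-bearing one, gives a 1.3-fold lower number from compound 1 to compound 3 (0.10 log units; within the scatter) and so also cannot be read as a difference. Nothing at hand gives a reason for either result.

From the compounds shown here alone, whether an amine or a carboxylic acid in place of the hydroxy group, or a longer chain on that sulfur, would give a step beyond the scatter stays open.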